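Swapping a methoxyphenyl for iodine on a shared core

The compounds below may be only part of what the source reports. "The series", "measured", "known", "first", "only" and "open" are said of these compounds alone.

Compound 1 `Cc1cc(-c2ccccc2)c2ncc(CSCCc3ccccc3)n2c1` is the plainest of the measured set, and in an ADME assay on HEL cells (Homo sapiens) for cytotoxicity, with a stated time of 3 days (a lower number here means that less compound is tolerated, a higher number that more compound is tolerated), compound 1 gives 33 ug/mL. Compound 2 `COc1cccc(-c2cc(C)c3ncc(CSCCc4ccccc4)n3c2)c1` differs by a methoxy on an aromatic carbon, and in this assay compound 2 gives 36 ug/mL, a number that lies within the usual scatter of compound 1. Compound 3 `COc1cccc(-c2cc(C)cn3c(CSCCc4ccccc4)cnc23)c1` also carries a methoxyphenyl; in this assay compound 3 reports only > 50 ug/mL, which is a limit of the assay and not a number. the limit of > 50 ug/mL in this assay, at which 1 of the 3 values shown sits, marks that edge. Among the compounds with values here, the one measured step, an at least 1.5-fold higher number from compound 1 to compound 3 (0.18 log units; that floor lies within the scatter), concerns a methoxy alone. Compound 4 `Cc1cc(I)cn2c(CSCCc3ccccc3)cnc12` is unmeasured; its change from compound 2 is iodo in place of 3-methoxyphenyl on an aromatic carbon. Within the data shown here, no measured step touches an exchange of this kind, so nothing in the numbers points in either direction beyond the scatter. Compound 4 is therefore expected to give about 40 ug/mL, between 22 ug/mL and 70 ug/mL, a step of a 1.1-fold higher number from compound 2 to compound 4 (0.05 log units; within the scatter) that is estimated to remain within the scatter.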

Compound 4, half-maximal cytotoxic concentration: > 50 ug/mL
Compound 4: no number, only a limit; the forecaster's own chance of this, stated with the estimate: 35%; at least 1.2-fold (0.09 log units) between middle value and limit.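

In this assay compound 4 reports > 50 ug/mL, which is a limit of the assay and not a number. Even so, the exchange of 3-methoxyphenyl for iodo, which removes a whole aromatic ring from this position on the shared core, comes out as an at least 1.3-fold higher number from compound 2 to compound 4 (0.14 log units; that floor lies within the scatter), so no loss of tolerance appears, although the floor of this step does not by itself clear the usual scatter. The assay can no longer rank compounds that reach this edge: the limit of > 50 ug/mL in this assay, at which 2 of the 4 values shown sit.

The compounds shown leave open how an amine or a carboxylic acid at this position would behave, and whether either would bring the number down. They also leave open how far the true value of compound 4 lies from its limit.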